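A few compounds are considered here, and "the series" means these few. Any claim that something is new, unique, unknown or untested is made for them only; others in the source may bear on it.

Measured in a functional assay on PC-3 cells (Homo sapiens) for inhibition, read by MTT assay, with stated times of 18 h and 4 h; on this read-out higher numbers stand for weaker inhibition and lower numbers for stronger inhibition:
- compound 1 `CCCCCCCCCCCCCCCCOP(=O)(O)OCCSC(=S)N1CCCCCC1`: 32100 nM
- compound 2 `CCCCCCCCCCCCCCCCOP(=O)(O)OCCSC(=S)N1CCN(C)CC1`: 95200 nM
- compound 3 `CCCCCCCCCCCCCCCCOP(=O)(O)OCCSC(=S)N1CCCC1`: 65700 nM

Compound 2 cannot be told apart from compound 3, as a 1.4-fold lower number from compound 2 to compound 3 (0.16 log units; within the scatter) shows. Compound 1 gives the lower number against both, with a 3.0-fold higher number from compound 1 to compound 2 (0.47 log units; beyond the scatter) and a 2.0-fold higher number from compound 1 to compound 3 (0.31 log units; beyond the scatter).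

The next compound is compound 4 `CCCCCCOP(=O)(O)OCCSC(=S)N1CCN(C)CC1`. It keeps the ring of compound 2 and changes only the chain on the phosphate: hydrogen in place of decyl on a saturated chain carbon, six bonds along the chain from an oxygen on an unsaturated carbon. In words, this is hydrogen in place of decyl on a saturated chain carbon, six bonds along the chain from an oxygen on an unsaturated carbon.

Among the measured compounds shown here, none of the measured steps touches the chain. All three swap the ring on the thiocarbonyl carbon, so they show only how far the series moves under a ring change, and that is modest in a 3.0-fold higher number from compound 1 to compound 2 (0.47 log units; beyond the scatter). For the measured compounds named here, no measured pair shows the effect of shortening the chain, and the direction here is a judgement. The change removes far more of the structure than any ring swap. A step towards weaker inhibition is expected, probably no smaller than the ring steps. The expected move is a 2.0-fold higher number from compound 2 to compound 4 (0.30 log units; within the scatter). For compound 4 the estimated value is 190000 nM, with an expected range of 70000 nM to 500000 nM.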

Compound 4, half-maximal inhibitory concentration: > 100000 nM
Compound 4 was reported as a limit; the forecaster's own chance of this, stated with the estimate: 40%; the middle value lies beyond the limit too.
By their numbers in this assay, from the lowest: compound 1; then compounds 3 and 2 (each within the scatter of the next). At a limit, above all of these: compound 4.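

In this assay compound 4 is reported only as a limit, > 100000 nM, and not as a number. This is the first change shown on the chain rather than on the ring, and all that can be read from it is a floor, an at least 1.0-fold higher number from compound 2 to compound 4 (0.02 log units; that floor lies within the scatter), so the replacement of decyl by hydrogen gives no sign of a lower number, while the size of any rise stays unread. The ring steps therefore remain the only measured moves in the series, and the chain change adds a bound on one side only, resting on a single reading of this kind: the limit of > 100000 nM in this assay, at which 1 of the 4 values shown sits.

Still open, going by these compounds, is how the number moves along the chain: a chain of intermediate length, or a longer chain than that of compound 2, would be needed to turn this bound into a measured step. Also open, on these data alone, is whether the same shortening on the azepan-1-yl ring of compound 1 would give a readable number, and whether an amine or a carboxylic acid at the chain end would change the picture.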